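The compounds below may be only part of what the source reports. "The series", "measured", "known", "first", "only" and "open" are said of these compounds alone.

Working notes on the series. In a functional assay on HeLa cells (Homo sapiens) for antiproliferative activity, read by MTT assay, with a stated time of 72 h (on this read-out lower numbers stand for stronger inhibition and higher numbers for weaker inhibition), compound 1 (`CCCC(=O)NNC(=O)c1csc2ncc(-c3ccc(OC)cc3)n12`) gives 43300 nM. Going by the values given here, compound 2 (`CCC(=O)NNC(=O)c1csc2ncc(-c3ccc(Br)cc3)n12`) gives 23100 nM, which lies within the scatter of the value of compound 1, so compound 2 does not stand apart from the only other measured compound. The unmeasured compound 3 (`CCCC(=O)NNC(=O)c1csc2ncc(-c3ccc(Br)cc3)n12`) differs from compound 2 at one place: methyl in place of hydrogen on a saturated chain carbon, two bonds along the chain from a carbonyl carbon, which also reads as propanoyl to propylcarbonyl (methyl in place of hydrogen on a saturated chain carbon, two bonds along the chain from a carbonyl carbon). Among the compounds with values here, no measured pair isolates this change, so the data give no direct size for it. In this assay no step beyond the scatter is expected, and no direction is favoured. The expected change is a 1.1-fold higher number from compound 2 to compound 3 (0.03 log units; within the scatter). For compound 3 the estimated value is 25000 nM, with an expected range of 10000 nM to 60000 nM.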

Compound 3, half-maximal inhibitory concentration: 31900 nM
The estimate for compound 3 lay 1.3-fold (0.11 log units) below the measured number; low and high end bracket the measured number.
By their numbers in this assay, from the lowest: compounds 2, 3 and 1 (each within the scatter of the next).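

Methyl in place of hydrogen on a saturated chain carbon, two bonds along the chain from a carbonyl carbon, gives in this assay a 1.4-fold higher number from compound 2 to compound 3 (0.14 log units; within the scatter), so this first direct measure of the propanoyl to propylcarbonyl change shows no effect that can be told from the scatter. Compound 3 also isolates the aromatic place, where bromo in place of methoxy on an aromatic carbon gives a 1.4-fold lower number from compound 1 to compound 3 (0.13 log units; within the scatter), and neither of these two single changes separates its pair of compounds. No supporting data bear on either step.

As far as these compounds go, whether a longer chain, or a chain carrying an amine or a carboxylic acid, would give a step beyond the scatter stays open. The same holds for aromatic groups other than bromo and methoxy, such as trifluoromethyl or nitrile.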